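Bromo in place of chloro in the aryl series

The source may hold more compounds than are shown below. What is called first, only, known or untested is meant among the compounds shown, and "the series" means these compounds.

Compound 3 (`Nc1nc(NCCNc2ncc(-c3ncc[nH]3)c(-c3ccc(F)cc3Cl)n2)ccc1[N+](=O)[O-]`) has no readable number in an ADME assay on microsomes from liver (Canis lupus familiaris) for metabolic stability; on this read-out higher numbers stand for a longer-lived compound and lower numbers for a shorter-lived compound. Compound 3 gives > 0.5 h, which is a limit. Compound 1 (`Nc1nc(NCCNc2ncc(-c3ncc[nH]3)c(-c3ccc(C(F)(F)F)cc3)n2)ccc1[N+](=O)[O-]`) gives > 0.5 h, also a limit. Compound 2 (`Nc1nc(NCCNc2ncc(-c3ncc[nH]3)c(-c3cc(F)c(F)cc3F)n2)ccc1[N+](=O)[O-]`) gives > 0.5 h, again a limit. The whole set therefore stands at the limit of > 0.5 h in this assay, at which 3 of the 3 values shown sit.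

Compound 4 (`Nc1nc(NCCNc2ncc(-c3ncc[nH]3)c(-c3ccc(F)cc3Br)n2)ccc1[N+](=O)[O-]`) carries bromo in place of chloro on an aromatic carbon.

The measured steps that bear on this change alter the same aryl group. They are a step that the two limits leave unreadable from compound 2 to compound 3, a step that the two limits leave unreadable from compound 1 to compound 3 and a step that the two limits leave unreadable from compound 1 to compound 2. None of them has a readable size, so they offer no basis for a direction. No step beyond the scatter is expected in this assay, and another report as a limit is the likely outcome.

The expected change is a step that the limit leaves unreadable from compound 3 to compound 4.

For compound 4 the estimate is 0.9 h, with an expected range from 0.5 h to 2 h.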

Compound 4, half-life: > 0.5 h
Compound 4: a limit, no number; the forecaster's own chance of this, stated with the estimate: 80%; the middle value lies beyond the limit too.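

No step can be read between compound 4 and compound 1, compound 2 or compound 3, since all four report only a limit in this assay: the limit of > 0.5 h in this assay, at which 4 of the 4 values shown sit.

The compounds shown leave open how long each one actually lasts, and whether bromo and chloro differ at all on this read-out.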